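This account rests on a few compounds, and the source may have more. Where it says the series, first, only, none or still open, it means among the compounds named here.

In an ADME assay on MT4 cells (Homo sapiens) for cytotoxicity, read by MTT assay, with a stated time of 5 days (a lower number here means that less compound is tolerated, a higher number that more compound is tolerated), compound 1 `CCNc1cc(Oc2c(OC)cc3cc(C#N)ccc3c2OC)nc(Nc2ccc(C#N)cc2)n1` gives > 125000 nM, which is a limit and not a number. Compound 2 `CCCC(C)Nc1cc(Oc2c(OC)cc3cc(C#N)ccc3c2OC)nc(Nc2ccc(C#N)cc2)n1` gives > 125000 nM, again a limit. Compound 3 `COc1cc2cc(C#N)ccc2c(OC)c1Oc1cc(NCC2CCOCC2)nc(Nc2ccc(C#N)cc2)n1` gives > 125000 nM, also a limit, so its true value is not known. All the data so far rest on (the limit of > 125000 nM in this assay, at which 3 of the 3 values shown sit).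

Compound 4 `COc1cc2cc(C#N)ccc2c(OC)c1Oc1cc(NCCCO)nc(Nc2ccc(C#N)cc2)n1` differs from compound 3 by having 2-hydroxyethyl in place of oxan-4-yl on a saturated chain carbon bound to a nitrogen on an aromatic ring. Put another way, (oxan-4-yl)methyl becomes 3-hydroxypropyl.

The measured steps that bear on this change the same side chain: a step that the two limits leave unreadable from compound 1 to compound 2, a step that the two limits leave unreadable from compound 1 to compound 3 and a step that the two limits leave unreadable from compound 2 to compound 3. None has a readable size, but none of these compounds gave a number below the limit. No step beyond the usual scatter is therefore expected in this assay, in either direction, although this expectation is weakly supported.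

The expected change is a number no higher from compound 3 to compound 4 (the limit leaves the size open). For compound 4, the estimated value is 125000 nM, with an expected range from 50000 nM to 125000 nM.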

Compound 4, half-maximal cytotoxic concentration: 23500 nM
Compound 4: middle estimate off by 5.3-fold (0.73 log units), on the high side; the measured number lies below the stated range.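

In this assay, among the compounds shown here, compound 4 is the first compound here to give a number instead of a limit, which shows that the group on this nitrogen can change how much compound the cells tolerate. The change reads as an at least 5.3-fold lower number from compound 3 to compound 4 (0.72 log units; beyond the scatter), and also as an at least 5.3-fold lower number from compound 2 to compound 4 (0.72 log units; beyond the scatter) and an at least 5.3-fold lower number from compound 1 to compound 4 (0.72 log units; beyond the scatter). Each of these steps gives only the smallest possible size, because the other three compounds stop at the same limit: the limit of > 125000 nM in this assay, at which 3 of the 4 values shown sit.

The steps among compounds 1, 2 and 3 cannot be read. On these data alone, it remains open whether the lower number goes with the hydroxyl group of 3-hydroxypropyl or with the chain itself, a question that a plain propyl group or 3-aminopropyl on the same nitrogen would address.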